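The source may hold more compounds than are shown below. What is called first, only, known or untested is meant among the compounds shown, and "the series" means these compounds.

Measured so far:
compound 1 `CC(C)n1ncc2c(C(=O)Nc3ccccc3)cccc21` — 11900 nM
compound 2 `CC(C)n1ncc2c(C(=O)Nc3cccnc3)cccc21` — > 40000 nM

In a functional assay on PC-3 cells (Homo sapiens) for inhibition, read by MTT assay, with a stated time of 72 h (a lower number here means a stronger inhibitor, a higher number a weaker inhibitor), compound 2 gives no number at all: its value sits at the limit of > 40000 nM in this assay, at which 1 of the 2 values shown sits, which is a limit of the measurement. The one measured step, an at least 3.3-fold higher number from compound 1 to compound 2 (0.52 log units; beyond the scatter), shows that swapping phenyl for pyridin-3-yl on the amide nitrogen weakened inhibition, so compound 2 is the weaker of the two compounds shown. Compound 3 `CC(C)n1ncc2c(C(=O)NC3CCCC3)cccc21` carries the change (cyclopentyl in place of pyridin-3-yl on an amide-type nitrogen). For the measured compounds named here, only the step from compound 1 to compound 2 bears on this, and it points in the opposite direction: taking the pyridin-3-yl away again is expected to undo at least part of that loss, though cyclopentyl is not phenyl, so how far the number returns is uncertain. The step of an at least 2.6-fold lower number from compound 2 to compound 3 (0.42 log units; beyond the scatter) is therefore expected to be a modest recovery. Compound 3 is estimated at 15000 nM in this assay, within 5000 nM to 60000 nM.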

Compound 3, half-maximal inhibitory concentration: 19400 nM
Compound 3: the middle estimate sits 1.3-fold (0.11 log units) below what was measured, and the stated range covers the measured number.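

Replacing phenyl with cyclopentyl on the amide nitrogen gives a 1.6-fold higher number from compound 1 to compound 3 (0.21 log units; within the scatter), so at this position an aromatic ring is not required to keep the activity of compound 1. For the compounds shown here, replacing pyridin-3-yl with cyclopentyl gives an at least 2.0-fold lower number from compound 2 to compound 3 (0.31 log units; beyond the scatter), which leaves pyridin-3-yl as the one group of the three that stands apart from the other two. That step gives only a minimum size, not an exact one, since compound 2 has a limit and not a number: the limit of > 40000 nM in this assay, at which 1 of the 3 values shown sits.

The three compounds cannot show whether the loss comes from the ring nitrogen of pyridin-3-yl or from something else about that group. Nor do they show how an open chain such as butyl, or a phenyl ring carrying a methoxy group or a carboxylic acid, would behave on this nitrogen.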